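This account rests on a few compounds, and the source may have more. Where it says the series, first, only, none or still open, it means among the compounds named here.

In a functional assay (Homo sapiens) for inhibition (a lower number here means a stronger inhibitor, a higher number a weaker inhibitor), compound 1 `COc1ccc(C(=O)/C=C/c2cccc(N(C)C)c2)c(OC)c1OC` gives 26000 nM and compound 2 `COc1ccc(C(=O)/C=C/c2cccc([N+](=O)[O-])c2)c(OC)c1OC` gives 36000 nM. Going by the values given here, these two values lie within the usual scatter of each other, so compound 2 cannot be told apart from the only other compound measured so far. Compound 3 `COc1ccc(C(=O)/C=C/c2cccc(F)c2)c(OC)c1OC` keeps the shared core but carries fluoro in place of nitro on an aromatic carbon, meta to a large group: fluoro in place of nitro on an aromatic carbon. Among the compounds with values here, the one measured step that bears on this change is a 1.4-fold higher number from compound 1 to compound 2 (0.14 log units; within the scatter), with nitro in place of dimethylamino on an aromatic carbon. Within the data shown here, with only that small step to go on, and with compound 2 at 36000 nM, no change beyond the scatter is expected in this assay. The expected step is a 1.2-fold lower number from compound 2 to compound 3 (0.08 log units; within the scatter). Compound 3 is estimated at 30000 nM, within an expected range of 12000 nM to 70000 nM.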

Compound 3, half-maximal inhibitory concentration: 6400 nM
Estimate against measurement, compound 3: 4.7-fold (0.67 log units) above; measured number below the stated range.
By their numbers in this assay, from the lowest: compound 3; then compounds 1 and 2 (each within the scatter of the next).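

In this assay, the group at this place on the aromatic ring can matter after all: fluoro in place of nitro gives a 5.6-fold lower number from compound 2 to compound 3 (0.75 log units; beyond the scatter), and fluoro in place of dimethylamino gives a 4.1-fold lower number from compound 1 to compound 3 (0.61 log units; beyond the scatter). The earlier step, between nitro and dimethylamino, stayed within the scatter, so it gave no sign that this place could shift the number beyond it. Compound 3 now stands apart from compound 1 and compound 2, and nothing available explains that gap.

Going by these compounds alone, with only three compounds, it remains open whether the lower number belongs to fluoro itself or simply goes with a single heavy atom at this place. Chloro, methyl or a plain hydrogen on the same carbon would help separate those two readings.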